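From compound 2 to compound 4

The source may hold more compounds than are shown below. What is called first, only, known or untested is meant among the compounds shown, and "the series" means these compounds.

Measured in a functional assay on MCF7 cells (Homo sapiens) for inhibition, read by MTT assay, with a stated time of 72 h, tested at 50 uM; on this read-out lower numbers stand for less inhibition of growth and higher numbers for more inhibition of growth at the one concentration tested:
Compound 1 `C=CCc1cc(O)c(O)c(CN2CCC(C)CC2)c1`: 54.2%
Compound 2 `C=CCc1cc(O)c(O)c(CN2CCC(CCO)CC2)c1`: 33.3%
Compound 3 `C=CCc1ccc(OCc2cn(-c3ccccc3Cl)nn2)c(O)c1`: 34.3%

In this assay compound 2 gives 33.3%, and compound 3 gives 34.3%, so these two cannot be told apart within the scatter. Compound 1 stands clearly apart from compound 2. The next compound, compound 4 `C=CCc1cc(O)c(O)c(CN2CCC(CO)CC2)c1`, is still unmeasured. It differs from compound 2 as follows: hydroxy in place of hydroxymethyl on a saturated chain carbon bound to a saturated ring carbon. In words, this is hydroxy in place of hydroxymethyl on a saturated chain carbon bound to a saturated ring carbon, the same difference as 2-hydroxyethyl to hydroxymethyl. Among the compounds with values here, no measured pair carries this exact change. Within the data shown here, the only step that bears on it is a number 20.9 percentage points lower from compound 1 to compound 2 (beyond the scatter), and there the hydroxymethyl entered in place of hydrogen. Compound 4 keeps a hydroxy group on the chain, so a change of that size is not expected here, and only a small upward drift within the scatter is anticipated. The expected step is a number 4.7 percentage points higher from compound 2 to compound 4 (within the scatter). For compound 4 the estimated value is 38%, with an expected range from 23% to 54%.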

Compound 4, percent growth inhibition at one concentration: 32.3%
The estimate for compound 4 lay 5.7 percentage points above the measured number, within the range that was stated.
By their numbers in this assay, from the lowest: compounds 4, 2 and 3 (each within the scatter of the next); then compound 1.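

In this assay the change from 2-hydroxyethyl to hydroxymethyl gives a number 1 percentage points lower from compound 2 to compound 4 (within the scatter) and so does not separate these two chains at this position. Hydroxy in place of hydrogen gives a number 21.9 percentage points lower from compound 1 to compound 4 (beyond the scatter) and runs in the same direction as the step to compound 2, so both compounds with a hydroxy on this chain stand apart from compound 1. Nothing at hand explains this difference.

The compounds shown leave open whether the hydroxy group itself matters or whether other groups on this saturated chain carbon would give the same result. An amine, a carboxylic acid or a longer chain ending in hydroxy at this place would help to settle that.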